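This account rests on a few compounds, and the source may have more. Where it says the series, first, only, none or still open, it means among the compounds named here.

Compound 1 `CC(=O)Nc1cc(Oc2ccc(NC(=O)Nc3ccc(C)c(C(F)(F)F)c3)cc2)ncn1` carries an acetyl on the nitrogen attached to the shared core; in a functional assay on BaF3 cells (Mus musculus) for inhibition, read by CCK-8 assay, with a stated time of 72 h (a higher number here means a weaker inhibitor of growth, a lower number a stronger inhibitor of growth), compound 1 gives 3230 nM. Compound 2 `Cc1ccc(NC(=O)Nc2ccc(Oc3cc(N)ncn3)cc2)cc1C(F)(F)F` has hydrogen in place of that acetyl. In this assay compound 2 gives > 10000 nM, which is a limit of the assay and not a number. The measured step is an at least 3.0-fold higher number from compound 1 to compound 2 (0.49 log units; beyond the scatter). The pair thus already touches the assay ceiling: the limit of > 10000 nM in this assay, at which 1 of the 2 values shown sits.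

Compound 3 `Cc1ccc(NC(=O)Nc2ccc(Oc3cc(/N=C/N(C)C)ncn3)cc2)cc1C(F)(F)F` is the next step from compound 2: a group of 5 heavy atoms (3 carbon, 2 nitrogen; no ring) in place of one nitrogen atom, on an aromatic carbon. For the measured compounds named here, the change again covers the amino nitrogen with a larger group and takes away its hydrogen-bond donor, and the one measured step points the same way, since the covered nitrogen of compound 1 stood at the lower number in an at least 3.0-fold higher number from compound 1 to compound 2 (0.49 log units; beyond the scatter). Going by the values given here, no measured pair shows this particular group, so its own effect is unknown. The expected step, an at least 2.0-fold lower number from compound 2 to compound 3 (0.30 log units; that floor lies within the scatter), is a modest fall in the number. The estimate for compound 3 is 5000 nM, with a range from 1200 nM to 20000 nM.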

Compound 3, concentration for 50% growth inhibition: 6610 nM
Compound 3: middle estimate off by 1.3-fold (0.12 log units), on the low side, and the stated range covers the measured number.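

Against the free amino group, the group of 5 heavy atoms (3 carbon, 2 nitrogen) gives an at least 1.5-fold lower number from compound 2 to compound 3 (0.17 log units; that floor lies within the scatter), so this step alone does not establish a gain over compound 2. For the compounds shown here, the limit of compound 2 in this assay leaves that step readable only as a floor: the limit of > 10000 nM in this assay, at which 1 of the 3 values shown sits. Against the acetyl group, the same position gives a 2.0-fold higher number from compound 1 to compound 3 (0.31 log units; beyond the scatter), which is the first comparison here between two substituted nitrogens on a measured footing and shows that covering the amino nitrogen does not by itself set the number, since the group with no hydrogen-bond donor stands on the higher side of compound 1.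

The compounds shown leave open how far the number depends on the size of the group and how far on its kind, for instance with a propionyl or benzoyl group, a methyl carbamate or a simple methyl on the same nitrogen. They also leave open whether any group at this position can take the number well below that of compound 1, and whether the order of these three groups holds when the trifluoromethyl or the urea of the shared core is changed.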